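The compounds below may be only part of what the source reports. "The series", "measured", "known", "first", "only" and "open" are said of these compounds alone.

Three compounds of one shared core were tested in an ADME assay on HEK-293T cells (Homo sapiens) for cytotoxicity, read by resazurin assay, with a stated time of 30 h; a lower number here means that less compound is tolerated, a higher number that more compound is tolerated. Compound 1, `O=C(Nc1ccc(N=C2NCCN2)cc1)c1ccc(N=C2NCCN2)c(F)c1`, gives only a limit of the assay, > 200000 nM. Compound 2, `O=C(Nc1ccc(N=C2NCCN2)cc1)c1ccc(N=C2NCCN2)cc1F`, likewise reaches only the limit, > 200000 nM. Compound 3, `O=C(Nc1ccc(N=C2NCCN2)cc1Cl)c1ccc(N=C2NCCN2)cc1`, also stands at a limit, > 200000 nM, so no number is known for it; it sits together with the other two at the limit of > 200000 nM in this assay, at which 3 of the 3 values shown sit. Compound 4, `O=C(Nc1ccc(N=C2NCCN2)cc1F)c1ccc(N=C2NCCN2)cc1`, differs from compound 3 in one place: fluoro in place of chloro on an aromatic carbon. Going by the values given here, no measured step of this kind is available, so the expected step in this assay is a step that the limit leaves unreadable from compound 3 to compound 4, none beyond the scatter. Compound 4 is therefore expected to give 300000 nM in this assay, between 120000 nM and 800000 nM, most likely again only as a limit.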

Compound 4, half-maximal cytotoxic concentration: > 200000 nM
Compound 4 was reported as a limit (the forecaster's own chance of this, stated with the estimate: 85%); the middle value lies beyond the limit too.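

Going by these compounds alone, compound 3 and compound 4 both stand only at a limit, and no step from the one to the other can be read. The compounds shown leave open where the true value of any of them lies in this assay.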